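This account rests on a few compounds, and the source may have more. Where it says the series, first, only, none or still open, it means among the compounds named here.

In a functional assay on MCF7 cells (Homo sapiens) for inhibition, read by sulforhodamine B assay (on this read-out higher numbers stand for weaker inhibition and lower numbers for stronger inhibition), compound 1 `O=C1C=C(Nc2ccc(I)cc2)C(=O)c2c1nc1n2[C@H]2OC[C@@H](O)[C@H]2OC1` gives 2230 nM. For compound 2 `COc1cccc(NC2=CC(=O)c3nc4n(c3C2=O)[C@H]2OC[C@@H](O)[C@H]2OC4)c1` this assay reports only a limit, > 4000 nM. For compound 3 `O=C1C=C(NC2CCCCC2)C(=O)c2c1nc1n2[C@H]2OC[C@@H](O)[C@H]2OC1` it likewise reports only a limit, > 8000 nM, so compound 3 stands at the far end of the numbers shown. Compound 4 `CCCc1ccc(NC2=CC(=O)c3nc4n(c3C2=O)[C@H]2OC[C@@H](O)[C@H]2OC4)cc1` differs from it in one place: 4-propylphenyl in place of cyclohexyl on an amine nitrogen. The measured step that bears on this change is an at least 3.5-fold higher number from compound 1 to compound 3 (0.55 log units; beyond the scatter), which runs the other way, from an aromatic ring to cyclohexyl; the step that the two limits leave unreadable from compound 2 to compound 3 adds nothing readable. Restoring an aromatic ring is therefore expected to move the number down, and compound 4 is estimated at 3000 nM, in a range from 1200 nM to 8000 nM. The expected step this means, an at least 2.6-fold lower number from compound 3 to compound 4 (0.42 log units; beyond the scatter), should lie beyond the scatter.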

Compound 4, half-maximal inhibitory concentration: 4660 nM
Compound 4: the middle estimate sits 1.6-fold (0.19 log units) below what was measured; low and high end bracket the measured number.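

Putting propyl in place of iodo on the aromatic ring carries a readable penalty: a 2.1-fold higher number from compound 1 to compound 4 (0.32 log units; beyond the scatter). Against cyclohexyl, 4-propylphenyl gives an at least 1.7-fold lower number from compound 3 to compound 4 (0.23 log units; that floor lies within the scatter), so an aromatic ring at this amine nitrogen may help, but the data do not establish it. That step is only a floor because compound 3 carries a limit rather than a number: the limit of > 8000 nM in this assay, at which 1 of the 4 values shown sits.

The step between compound 2 and compound 4 cannot be read. As far as these compounds go, whether a longer chain or an amine in place of propyl would lower the number stays open.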